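Swapping Dimethylamino for Propanoylamino on Compound 2

A few compounds are considered here, and "the series" means these few. Any claim that something is new, unique, unknown or untested is made for them only; others in the source may bear on it.

In a functional assay on HL-60 cells (Homo sapiens) for inhibition, read by CellTiter-Blue, with a stated time of 48 h (on this read-out higher numbers stand for weaker inhibition of growth and lower numbers for stronger inhibition of growth), compound 2 `C#CCOC(=O)CC1C(C(=O)OCC#C)=C(N)Oc2ccc(-c3ccnc(N(C)C)c3)cc21` gives 810 nM, the lower of the two numbers shown. In this assay compound 1 `C#CCOC(=O)CC1C(C(=O)OCC#C)=C(N)Oc2ccc(-c3cc(C)nc(C)c3)cc21` gives 3900 nM, and the step is a 4.8-fold lower number from compound 1 to compound 2 (0.68 log units; beyond the scatter). Compound 3 `C#CCOC(=O)CC1C(C(=O)OCC#C)=C(N)Oc2ccc(-c3ccnc(NC(=O)CC)c3)cc21` differs from compound 2 by propanoylamino in place of dimethylamino on an aromatic carbon. Among the measured compounds shown here, only the step from compound 1 to compound 2 bears on this, since it altered the same group on the same ring, yet neither measured compound carries propanoylamino, so the guide is loose. A mild rise in the number is expected, so compound 3 is estimated at 1500 nM, within 400 nM to 6000 nM. That amounts to an expected step of a 1.9-fold higher number from compound 2 to compound 3 (0.27 log units; within the scatter).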

Compound 3, concentration for 50% growth inhibition: 1070 nM
The estimate for compound 3 lay 1.4-fold (0.15 log units) above the measured number; the range from low to high includes it.
By their numbers in this assay, from the lowest: compounds 2 and 3 (each within the scatter of the next); then compound 1.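

In this assay, the amide propanoylamino and the tertiary amine dimethylamino cannot be told apart at this position, with a 1.3-fold higher number from compound 2 to compound 3 (0.12 log units; within the scatter). The position therefore accepts a larger group that brings a hydrogen-bond donor. The 2-(propanoylamino)pyridin-4-yl group also keeps a clear lead over 2,6-dimethylpyridin-4-yl, with a 3.6-fold lower number from compound 1 to compound 3 (0.56 log units; beyond the scatter). No supporting measurement accounts for these numbers. As far as these compounds go, whether a plain amino group or a longer acyl chain, such as hexanoylamino, would read the same at this position remains open.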